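Trifluoromethyl for Fluoro on a Benzoxazole Sulfonamide

The compounds below may be only part of what the source reports. "The series", "measured", "known", "first", "only" and "open" are said of these compounds alone.

Of the compounds shown here, two of a shared core have been measured. Compound 1 `CCc1ccc(S(=O)(=O)Nc2ccc(-c3nc4ccccc4o3)cc2)cc1` was tested in an assay on cells for inhibition of HSP60/HSP10 (Homo sapiens), with a stated time of 60 min (on this read-out higher numbers stand for weaker inhibition and lower numbers for stronger inhibition), and gave only a limit, > 100000 nM, rather than a number. Within the data shown here, compound 2 `O=S(=O)(Nc1ccc(-c2nc3ccccc3o2)cc1)c1ccc(F)cc1` gave a number in this assay, 73000 nM, the only number among the values shown. Among the measured compounds shown here, the step of an at least 1.3-fold lower number from compound 1 to compound 2 (0.13 log units; that floor lies within the scatter) is the single measured step, and the limit of > 100000 nM in this assay, at which 1 of the 2 values shown sits, marks where the other value sits.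

Compound 3 `O=S(=O)(Nc1ccc(-c2nc3ccccc3o2)cc1)c1ccc(C(F)(F)F)cc1` differs from compound 2 in one place: trifluoromethyl in place of fluoro on an aromatic carbon. The measured step from compound 1 to compound 2 swapped one group for another on an aromatic carbon, and its floor lies within the scatter, so it gives little direction. For the measured compounds named here, nothing among the measured compounds indicates that the trifluoromethyl group would move the number beyond the scatter, so compound 3 is expected to stand close to compound 2 in this assay, with an estimated step of a 1.2-fold higher number from compound 2 to compound 3 (0.07 log units; within the scatter). Compound 3 is therefore estimated at 85000 nM, with a range from 30000 nM to 250000 nM, and the assay may again report only a limit.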

Compound 3, half-maximal inhibitory concentration: 50000 nM
For compound 3 the middle estimate is 1.7-fold (0.23 log units) above the measured one; the range from low to high includes it.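

Replacing fluoro with trifluoromethyl on the aromatic carbon para to a large group gives, in this assay, a 1.5-fold lower number from compound 2 to compound 3 (0.16 log units; within the scatter), so a group of 4 heavy atoms in place of 1 still gives a number at this position, and that number cannot be told apart from the one for fluoro. Set against ethyl at the same carbon, trifluoromethyl gives an at least 2.0-fold lower number from compound 1 to compound 3 (0.30 log units; that floor lies within the scatter), and this comparison likewise does not establish a difference between the two groups, since its floor does not clear the usual scatter. Compound 1 remains a limit of the assay and not a number, so the true size of both steps from it stays unknown: the limit of > 100000 nM in this assay, at which 1 of the 3 values shown sits.

The compounds shown leave open whether any group on this carbon can move the number beyond the scatter, since all of them so far are fluoro or carbon-based groups without hydrogen-bond donors or acceptors, and an amine, a carboxylic acid or a longer chain could test that. They also leave open whether a change elsewhere on the shared core would matter more than one at this position.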